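Indole ketonitriles with chlorodienyl aryl groups: inhibition notes

The compounds below may be only part of what the source reports. "The series", "measured", "known", "first", "only" and "open" are said of these compounds alone.

Measured compounds:
compound 1 `COc1ccc(/C(Cl)=C/C=C(\C#N)C(=O)c2c[nH]c3ccccc23)cc1`: 23.4%
compound 2 `Cc1[nH]c2ccccc2c1C(=O)/C(C#N)=C/C=C(\Cl)c1ccc(Br)cc1`: 15.8%
compound 3 `N#C/C(=C\C=C(/Cl)c1ccc(Br)cc1)C(=O)c1c[nH]c2ccc(Br)cc12`: 15.8%

All three numbers come from a functional assay for inhibition, with a stated time of 30 min, tested at 1 mM; on this read-out lower numbers stand for less inhibition and higher numbers for more inhibition at the one concentration tested (going by the name of the read-out). In this assay compound 1 gives 23.4%, compound 2 gives 15.8% and compound 3 gives 15.8%. The number for compound 1 is the largest of the three, but the gaps to compound 2 and to compound 3 both fall within the usual scatter, so the three compounds are not separated from one another by these data. Among the measured compounds shown here, no pair of measured compounds differs in only one place, so no single structural step has been measured.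

Compound 4 `COc1ccc(/C(Cl)=C/C=C(\C#N)C(=O)c2c[nH]c3ccccc23)cc1OC` is not yet measured. It differs from compound 1 by methoxy in place of hydrogen on an aromatic carbon. For the measured compounds named here, there is no measured step of this kind to lean on, so the expectation for this assay is a step of no size beyond the scatter in either direction. For compound 4 the estimated step is a number 0.6 percentage points higher from compound 1 to compound 4 (within the scatter). Compound 4 is therefore expected to give about 24% in this assay, with a range from 10% to 40%.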

Compound 4, a percentage reported as inhibition, at one concentration (the size of the read-out at that concentration, not a potency): 15.8%
For compound 4 the middle estimate is 8.2 percentage points above the measured one; low and high end bracket the measured number.
By their numbers in this assay, from the lowest: compounds 2, 3, 4 and 1 (each within the scatter of the next).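

In this assay, among the compounds shown here, methoxy in place of hydrogen on an aromatic carbon, ortho to a methoxy group and meta to a large group, gives a number 7.6 percentage points lower from compound 1 to compound 4 (within the scatter), and this is the first step measured at a single place. At this position, then, adding a methoxy group with its 2 heavy atoms to the core of compound 1 produces no change that this read-out can separate from the scatter, so a single step gives no sign that the position matters for the read-out in either direction. No information is available on what lies behind this result.

On these data alone, whether this position stays as unresponsive with a different kind of group, such as an amine, a carboxylic acid or a longer chain like butoxy, remains open. Also open, as far as these compounds go, is whether methoxy in place of hydrogen would give a similar step on the cores of compound 2 and compound 3, which carry other substituents elsewhere.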